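Swapping the Hexyl Amide of Compound 2 for a Piperidine Ring

A few compounds are considered here, and "the series" means these few. Any claim that something is new, unique, unknown or untested is made for them only; others in the source may bear on it.

Compound 1 `COc1cc2c(cc1OC)C(CC(=O)NC(C)C)CC2` and compound 2 `CCCCCCNC(=O)CC1CCc2cc(OC)c(OC)cc21` share one core and differ only at the amide nitrogen. In a functional assay on the whole organism (strain Wistar) for inhibition, with Rattus norvegicus as the target, read by paw edema, with stated times of 60 min and 3 h, at a dose of 100 mg/kg by the oral route (a lower number here means less inhibition, a higher number more inhibition at the dose given (going by the name of the read-out)), compound 1 gives 30.4%, while compound 2 gives 44.6%. For the measured compounds named here, the single step measured so far, a number 14.2 percentage points higher from compound 1 to compound 2 (beyond the scatter), shows the larger hexyl chain raising the read-out modestly. Going by the values given here, compound 2 therefore stands at the top of the two numbers, with compound 1 the only neighbour, a modest distance below.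

Compound 3 `COc1cc2c(cc1OC)C(CC(=O)N1CCCCC1)CC2` keeps the same core and carbonyl but changes the amide in a new way: piperidin-1-yl in place of hexylamino on a carbonyl carbon. The measured step from compound 1 to compound 2 bears on this only loosely, since it altered the size of an open chain rather than closing a ring and removing the amide hydrogen. Among the compounds with values here, no measured step shows what that closing does. A ring of roughly comparable size is expected to land somewhere near or a little below compound 2, so the step of a number 8.6 percentage points lower from compound 2 to compound 3 (within the scatter) is estimated to be small and downward. Compound 3 is thus expected to give about 36% in this assay, within a range from 15% to 55%.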

Compound 3, a percentage reported as inhibition, in the whole organism at one dose (the size of the read-out at that dose, not a potency): 31.9%
For compound 3 the middle estimate is 4.1 percentage points above the measured one, and the stated range covers the measured number.
By their numbers in this assay, from the lowest: compounds 1 and 3 (each within the scatter of the next); then compound 2.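

In this assay, piperidin-1-yl in place of hexylamino on a carbonyl carbon gives a number 12.7 percentage points lower from compound 2 to compound 3 (beyond the scatter) and shows that this position does not respond to group size alone, as the two groups are close in heavy-atom count. The change also closes a ring and removes the hydrogen-bond donor, so this single step cannot separate those two differences. Against the shorter isopropylamino group, the ring gives a number 1.5 percentage points higher from compound 1 to compound 3 (within the scatter) and so lies within the scatter, which leaves the hexylamino group of compound 2 as the only one of the three that stands apart, and no measurement available here explains this result.

Going by these compounds, whether a longer chain such as octylamino would carry the read-out further remains open. So does whether an open diethylamino group, which also lacks the amide hydrogen, would read like the piperidine ring.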